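Bromo in place of hydrogen on the shared core

The source may report more compounds than this note shows. Statements on the series, on what has been measured and on what is new or still open speak of the compounds shown alone.

Measured compounds:
compound 1 `OCC(CO)OCn1c(Cl)nc2cc(Cl)c(Cl)cc21` gives > 100000 nM in a functional assay on KB cells (Homo sapiens) for inhibition (on this read-out lower numbers stand for stronger inhibition and higher numbers for weaker inhibition), a limit of the assay.
compound 2 `CN(C)c1nc2cc(Cl)c(Cl)cc2n1COC(CO)CO` gives > 100000 nM in this assay, a limit of the assay.
compound 3 `OCC(CO)OCn1cnc2cc(Cl)c(Cl)cc21` gives > 100000 nM in this assay, a limit of the assay.

Compound 3 stands only at a limit: its value is not a number, and it shares that position with both other measured compounds (the limit of > 100000 nM in this assay, at which 3 of the 3 values shown sit). Compound 4 `OCC(CO)OCn1c(Br)nc2cc(Cl)c(Cl)cc21` differs from compound 3 by bromo in place of hydrogen on an aromatic carbon. The measured step that bears most on this is a step that the two limits leave unreadable from compound 1 to compound 3, the reverse exchange of a halogen for hydrogen at the same place; its size is not readable, since both ends are limits. The same holds for a step that the two limits leave unreadable from compound 1 to compound 2 and a step that the two limits leave unreadable from compound 2 to compound 3. Within the data shown here, no measured step therefore gives a readable size or direction, and nothing in the numbers suggests that the bromo group should move compound 4 away from the limit beyond the scatter of this assay. The expectation for compound 4 is that it again falls at or beyond the limit, with an estimated value of 200000 nM and a range from 50000 nM to 1000000 nM. The step that the limit leaves unreadable from compound 3 to compound 4 is accordingly expected to be flat, with a limit reading the most likely outcome.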

Compound 4, half-maximal inhibitory concentration: > 100000 nM
Compound 4: a limit, no number (the forecaster's own chance of this, stated with the estimate: 90%); the middle value is on the limit's open side.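

In this assay compound 4 gives > 100000 nM, a limit of the assay, so no new step can be read from compound 1, compound 2 or compound 3 to compound 4: the limit of > 100000 nM in this assay, at which 4 of the 4 values shown sit.

Left open is whether any group on that aromatic carbon of the shared core brings a compound to a readable number in this assay.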